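The source may report more compounds than this note shows. Statements on the series, on what has been measured and on what is new or still open speak of the compounds shown alone.

Measured so far in an ADME assay on microsomes from liver (Homo sapiens) for metabolic stability, read by LC-MS, with a stated time of 10 min; a higher number here means that more of the compound is left, a lower number that less of the compound is left
compound 1 `CN(C[C@H]1Cc2c(cccc2N2CCN(C3COC3)CC2)CN1)[C@H]1CCCc2cccnc21` with 83.1%
compound 2 `CN(C[C@H]1Cc2c(cccc2N2CCNC(C)(C)C2)CN1)[C@H]1CCCc2cccnc21` with 100%
compound 3 `CN(C[C@H]1Cc2c(cccc2N2CCN3CCC[C@H]3C2)CN1)[C@H]1CCCc2cccnc21` with 36.6%

Compound 3 stands lowest of the three at 36.6% and is the starting point here. Compound 4 `CN(C[C@H]1Cc2c(cccc2N2C[C@@H]3C[C@H]2CN3)CN1)[C@H]1CCCc2cccnc21` differs from it on an aromatic carbon of a six-membered aromatic ring of carbon only. The change is a group of 7 heavy atoms (5 carbon, 2 nitrogen; 2 five-membered non-aromatic rings with 1 hetero atom each) in place of a group of 9 heavy atoms (7 carbon, 2 nitrogen; one five-membered non-aromatic ring with 1 hetero atom, one six-membered non-aromatic ring with 2 hetero atoms), on an aromatic carbon and the shared core stays the same. Three measured steps at that carbon bear on it. Both a number 46.5 percentage points lower from compound 1 to compound 3 (beyond the scatter) and a number 63.4 percentage points lower from compound 2 to compound 3 (beyond the scatter) are large, while a number 16.9 percentage points higher from compound 1 to compound 2 (beyond the scatter) is modest. Neither compound 1 nor compound 2 carries the entering group, so the guidance is loose. Compound 1 at 83.1% and compound 2 at 100% both stand higher than compound 3, so a large rise is expected. The expected change is a number 38.4 percentage points higher from compound 3 to compound 4 (beyond the scatter) by this estimate. For compound 4 the estimate is 75% with 50% to 98% as the expected range.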

Compound 4, percent of the compound remaining: 100%
Compound 4: the middle estimate sits 25 percentage points below what was measured; measured number outside the range, above it.
By their numbers in this assay, from the lowest: compound 3; then compound 1; then compounds 2 and 4 (each within the scatter of the next).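

In this assay, the group with two five-membered non-aromatic rings on this aromatic carbon removes the weakness of compound 3, giving a number 63.4 percentage points higher from compound 3 to compound 4 (beyond the scatter). Measured against the other two groups, it gives no change at the digits printed from compound 2 to compound 4 (within the scatter) and a number 16.9 percentage points higher from compound 1 to compound 4 (beyond the scatter), so a smaller group at this carbon matches the best number shown here. No measurement at hand explains this result. The compounds shown leave open how a morpholin-4-yl group or an open-chain amine would fare at this carbon, and whether the other stereoisomers of the entering group would give the same number.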